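The source may hold more compounds than are shown below. What is called first, only, known or untested is meant among the compounds shown, and "the series" means these compounds.

Working notes on the series.

Compound 2 `CCOC(=O)C1=CCCCC1S(=O)(=O)Cc1ccccc1F` gives 97 nM in a functional assay on RAW264.7 cells (Mus musculus), read by fluorescence; on this read-out higher numbers stand for weaker inhibition and lower numbers for stronger inhibition. Compound 1 `CCOC(=O)C1=CCCCC1S(=O)(=O)Cc1ccc(Cl)cc1F` differs from it by chloro in place of hydrogen on an aromatic carbon and in this assay compound 1 gives 104 nM, a step of a 1.1-fold higher number from compound 2 to compound 1 (0.03 log units; within the scatter). Compound 3 `CCOC(=O)C1=CCCCC1S(=O)(=O)Cc1cccc(Cl)c1` carries a different aryl group, (3-chlorophenyl in place of 2-fluorophenyl on a saturated chain carbon bound to a sulfonyl sulfur); in this assay compound 3 gives 14 nM, a step of a 6.9-fold lower number from compound 2 to compound 3 (0.84 log units; beyond the scatter).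

Compound 4 `CCOC(=O)C1=CCCCC1S(=O)(=O)Cc1cccc(Cl)c1Cl` is not yet measured. It differs from compound 3 by chloro in place of hydrogen on an aromatic carbon. This is the same kind of change as that from compound 2 to compound 1, but the surroundings differ: there the entering chloro was meta to a fluoro group and para to a large group, here it is ortho to a chloro group and ortho to a large group. Within the data shown here, the single earlier instance stayed within the scatter, so the step from compound 3 to compound 4 is expected to be small as well, about a 1.1-fold higher number from compound 3 to compound 4 (0.06 log units; within the scatter). Compound 4 is therefore estimated at 16 nM, expected between 6 nM and 45 nM.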

Compound 4, half-maximal inhibitory concentration: 65 nM
Estimate against measurement, compound 4: 4.1-fold (0.61 log units) below; the whole stated range lies below it.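

Chloro in place of hydrogen on an aromatic carbon gives a 4.6-fold higher number from compound 3 to compound 4 (0.67 log units; beyond the scatter) in this assay, so this change does not carry over from one core to the other at a fixed size: the same change on two cores in this assay, a 1.1-fold higher number (0.03 log units; within the scatter) from compound 2 to compound 1 and a 4.6-fold higher number (0.67 log units; beyond the scatter) from compound 3 to compound 4, 4.3-fold (0.64 log units) apart, beyond the scatter of two such steps

The step weakens inhibition on the core of compound 3, whereas the earlier step shows no change beyond the scatter. The aryl groups and the places of the entering chloro both differ between the two pairs, and these two steps cannot separate those differences or establish a rule for the series.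

The compounds shown leave open how a methyl or methoxy group would compare with chloro ortho to a chloro group and ortho to a large group. They also leave open whether the step holds when a carboxylic acid or an amide stands in place of the ethyl ester.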